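The compounds below may be only part of what the source reports. "The series", "measured", "known", "first", "only" and "open" are said of these compounds alone.

Of the compounds shown here, two have been measured in a functional assay for antagonist activity at transient receptor potential cation channel subfamily V member 1 (Homo sapiens), read by FLIPR and calcium flux; a higher number here means a weaker inhibitor, a lower number a stronger inhibitor. Compound 1 `CCOC(=O)C1(C)Oc2ccc(NC(=O)C3CCN(c4cc(F)c(F)c(F)c4)CC3)cc2NC1=O` gives 870 nM. Compound 2 `Cc1ccccc1N1CCC(C(=O)Nc2ccc3c(c2)NC(=O)CO3)CC1` gives 150 nM, the lower of the two numbers, and the gap to compound 1 lies beyond the usual scatter, so compound 2 is the stronger inhibitor of the pair. Compound 3 `COc1cccc(N2CCC(C(=O)Nc3ccc4c(c3)NC(=O)CO4)CC2)c1` differs from compound 2 in one place: 3-methoxyphenyl in place of 2-methylphenyl on an amine nitrogen in a ring. Among the compounds with values here, no measured pair shows this change. In this assay the expected step is a 1.7-fold higher number from compound 2 to compound 3 (0.22 log units; within the scatter), a slight rise at most, possibly none beyond the scatter. Compound 3 is estimated to give 250 nM, within a range from 80 nM to 800 nM.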

Compound 3, half-maximal inhibitory concentration: 1420 nM
For compound 3 the middle estimate is 5.7-fold (0.75 log units) below the measured one, and the stated range ends below it.
By their numbers in this assay, from the lowest: compound 2; then compounds 1 and 3 (each within the scatter of the next).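

On the amine nitrogen in a ring, replacing 2-methylphenyl with 3-methoxyphenyl is not a neutral change: in this assay it gives a 9.5-fold higher number from compound 2 to compound 3 (0.98 log units; beyond the scatter) and a clearly weaker inhibitor. Within the data shown here, the earlier pair differed in more than one place, so this is the first direct reading of this position, and it shows that the aromatic group on this nitrogen can move the result beyond the scatter. The change swaps both the group on the phenyl ring and its location, and 3-methylphenyl or 2-methoxyphenyl would be needed to separate the two. No measurement here explains the step.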